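The compounds below may be only part of what the source reports. "The series", "measured", "known", "first", "only" and "open" are said of these compounds alone.

Measured in a functional assay on JeKo-1 cells (Homo sapiens) for inhibition, read by luminescence and CellTiter-Glo, with a stated time of 72 h; a higher number here means a weaker inhibitor, a lower number a stronger inhibitor:
Compound 1 `C/C=C/C(=O)Nc1cccc(Cn2nc(-c3ccc(Oc4ccccc4)cc3)cc2C(=O)O)c1`: > 60000 nM, a limit of the assay and not a number
Compound 2 `C/C=C/C(=O)Nc1cccc(Cn2nc(-c3ccc(Oc4ccccc4)cc3)cc2CO)c1`: 22600 nM
Compound 3 `C/C=C/C(=O)Nc1cccc(Cn2nc(-c3ccc(Oc4ccccc4)cc3)cc2C(=O)OCC)c1`: 16700 nM

Compound 2 stands level with compound 3, with a 1.4-fold lower number from compound 2 to compound 3 (0.13 log units; within the scatter), which lies within the scatter. Compound 4 `C=CC(=O)Nc1cccc(Cn2nc(-c3ccc(Oc4ccccc4)cc3)cc2CO)c1` differs from compound 2 in one place: vinyl in place of prop-1-en-1-yl on a carbonyl carbon. Going by the values given here, no measured step touches this group. The steps of an at least 2.6-fold lower number from compound 1 to compound 2 (0.42 log units; beyond the scatter) and an at least 3.5-fold lower number from compound 1 to compound 3 (0.55 log units; beyond the scatter) are at least modest, but both change the carboxy group and give no size for this change. The expectation therefore rests on compound 2 at 22600 nM. The expected step is a 1.3-fold lower number from compound 2 to compound 4 (0.10 log units; within the scatter), with none beyond the scatter foreseen. For compound 4 the estimated value is 18000 nM, with an expected range from 6000 nM to 45000 nM.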

Compound 4, half-maximal inhibitory concentration: 5200 nM
For compound 4 the middle estimate is 3.5-fold (0.54 log units) above the measured one, outside the stated range (below it).
By their numbers in this assay, from the lowest: compound 4; then compounds 3 and 2 (each within the scatter of the next). At a limit, above all of these: compound 1.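

In this assay the group on the carbonyl carbon proves to matter: vinyl in place of prop-1-en-1-yl gives a 4.3-fold lower number from compound 2 to compound 4 (0.64 log units; beyond the scatter), the only step shown at this place. The earlier steps shown here all changed the carboxy group and gave no size for a change here. Nothing shown gives a cause for this step.

As far as these compounds go, it remains open whether the same change holds when the hydroxymethyl is replaced by carboxy or ethoxycarbonyl. From the compounds shown here alone, what a longer chain or an amine-bearing chain on this carbonyl carbon would give also remains open.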